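A few compounds are considered here, and "the series" means these few. Any claim that something is new, unique, unknown or untested is made for them only; others in the source may bear on it.

Compound 1 `COc1cc(OCc2cccc(-c3ccc(C#N)cc3)c2)c2cc(-c3cn4nc(OC)sc4n3)oc2c1` is the reference point. In an ADME assay on the whole organism (Rattus norvegicus), at a dose of 2 mg/kg by the oral route (on this read-out higher numbers stand for higher exposure at the dose given and lower numbers for lower exposure), compound 1 gives 610 ng.h/mL. Two close relatives were measured alongside it: compound 2 `COc1cc(OCc2cccc(-c3ccc(C(F)(F)F)cn3)c2)c2cc(-c3cn4nc(OC)sc4n3)oc2c1` gives 459 ng.h/mL, and compound 3 `COc1cc(OCc2cccc(-c3ccc(C#N)cn3)c2)c2cc(-c3cn4nc(OC)sc4n3)oc2c1` gives 464 ng.h/mL. The step from compound 1 to compound 2 is a 1.3-fold lower number from compound 1 to compound 2 (0.12 log units; within the scatter), and the step from compound 1 to compound 3 is a 1.3-fold lower number from compound 1 to compound 3 (0.12 log units; within the scatter), so compound 1 sits within the usual scatter of both of its neighbours, and the step from compound 2 to compound 3 is a 1.0-fold higher number from compound 2 to compound 3 (0.00 log units; within the scatter). Compound 4 `COc1cc(OCc2cccc(-c3cnc(OC)nc3)c2)c2cc(-c3cn4nc(OC)sc4n3)oc2c1` differs from compound 1 by the change (2-methoxypyrimidin-5-yl in place of 4-cyanophenyl on an aromatic carbon). The two measured steps that bear on it, from compound 1 to compound 2 and from compound 1 to compound 3, each swapped the 4-cyanophenyl for a six-membered aromatic ring holding hetero atoms and stayed within the scatter. Compound 4 is therefore expected to land close to compound 1, the estimated step being a 1.3-fold lower number from compound 1 to compound 4 (0.10 log units; within the scatter). For compound 4 the estimate in this assay is 480 ng.h/mL, in the range from 230 ng.h/mL to 1000 ng.h/mL.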

Compound 4, area under the concentration-time curve: 1030 ng.h/mL
For compound 4 the middle estimate is 2.1-fold (0.33 log units) below the measured one; the measured number lies above the stated range.
By their numbers in this assay, from the lowest: compounds 2, 3, 1 and 4 (each within the scatter of the next, the first and the last beyond it).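

In this assay the position, on an aromatic carbon meta to a large group, now shows that the ring placed there can matter: the step to 2-methoxypyrimidin-5-yl gives a 2.2-fold higher number from compound 3 to compound 4 (0.35 log units; beyond the scatter) and a 2.2-fold higher number from compound 2 to compound 4 (0.35 log units; beyond the scatter), both modest. The same group gives a 1.7-fold higher number from compound 1 to compound 4 (0.23 log units; within the scatter), so it cannot be told apart from 4-cyanophenyl on this read-out, and the separation holds only against the two pyridin-2-yl groups. Nothing available here explains these differences.

The compounds shown do not separate the methoxy group from the pyrimidine ring, since the two enter together in a single change. As far as these compounds go, it remains open how exposure would respond to an amine, such as dimethylamino, or a carboxylic acid on the pyrimidine ring in place of the methoxy group.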